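Series notes: chloro in place of nitro, one step

This account rests on a few compounds, and the source may have more. Where it says the series, first, only, none or still open, it means among the compounds named here.

Measured compounds:
compound 1 `COc1cc(OC)c(OC)cc1/C=C/C(=O)c1ccc(O)cc1O`, 2.76 ug/mL
compound 2 `COc1cc(OC)c(OC)cc1/C=C/C(=O)c1ccc([N+](=O)[O-])cc1`, 1.98 ug/mL
compound 3 `COc1cc(OC)c(OC)cc1/C=C/C(=O)c1cccc(C(F)(F)F)c1`, 2.09 ug/mL

All three were read in a functional assay, read by Griess assay, with a stated time of 2.5 h; a higher number here means a weaker inhibitor, a lower number a stronger inhibitor. Compound 2 carries the lowest of the three numbers, but its gap to compound 3 and its gap to compound 1 both lie within the usual scatter, so the three compounds cannot be put in any order on these data. Within the data shown here, no pair of measured compounds differs in one place only, so no single step between measured compounds is available.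

Compound 4 `COc1cc(OC)c(OC)cc1/C=C/C(=O)c1ccc(Cl)cc1` is not yet measured. It differs from compound 2 in one place: chloro in place of nitro on an aromatic carbon. Nothing measured in the series bears on a change of this kind, and the three measured values sit so close together that the series gives no direction to follow. The step in this assay is therefore expected to be small, not beyond the scatter, in either direction. Compound 4 is expected to give about 2.5 ug/mL, within 1.2 ug/mL to 5 ug/mL. The expected step is a 1.3-fold higher number from compound 2 to compound 4 (0.10 log units; within the scatter), which stays within the scatter.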

Compound 4, half-maximal inhibitory concentration: 2.01 ug/mL
For compound 4 the middle estimate is 1.2-fold (0.09 log units) above the measured one, within the range that was stated.
By their numbers in this assay, from the lowest: compounds 2, 4, 3 and 1 (each within the scatter of the next).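

In this assay, swapping nitro for chloro, para to a large group, gives a 1.0-fold higher number from compound 2 to compound 4 (0.01 log units; within the scatter) and shows that this position tolerates the exchange of these two groups without a readable shift, although they differ in size and hydrogen-bond acceptor count. Exchange of the whole group on the carbonyl carbon, 4-chlorophenyl in place of 2,4-dihydroxyphenyl, gives a 1.4-fold lower number from compound 1 to compound 4 (0.14 log units; within the scatter) and likewise leaves the two compounds unseparated. No independent measurement accounts for these two readings.

On these data alone, whether an amine or a carboxylic acid at this position would move the number beyond the scatter remains open. Also open, as far as these compounds go, is whether a longer chain on this aromatic carbon would leave the reading as unchanged as chloro and nitro do.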